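Methoxy in place of hydrogen on a cytotoxicity screen

The compounds below may be only part of what the source reports. "The series", "measured", "known", "first", "only" and "open" are said of these compounds alone.

Measured compounds:
compound 1, `N/C(=N/O)c1ccc(C2=C(S(=O)(=O)c3ccc(F)cc3)CC(c3ccccc3)(c3ccccc3)O2)cc1`: 19200 nM
compound 2, `CC1(c2ccc(-c3ccc(/C(N)=N\O)cc3)cc2)CC(S(=O)(=O)c2ccc(F)cc2)=C(c2ccc(/C(N)=N\O)cc2)O1`: 15300 nM

In an ADME assay on HepG2 cells (Homo sapiens) for cytotoxicity, read by MTT assay, with a stated time of 72 h (a lower number here means that less compound is tolerated, a higher number that more compound is tolerated), compound 1 gives 19200 nM, the higher of the two numbers, while compound 2 gives 15300 nM, a gap within the scatter, so no order between them is claimed. Compound 3, `COc1ccc(C2(c3ccccc3)CC(S(=O)(=O)c3ccc(F)cc3)=C(c3ccc(/C(N)=N\O)cc3)O2)cc1`, has not yet been measured in this assay. It differs from compound 1 by methoxy in place of hydrogen on an aromatic carbon. For the measured compounds named here, no measured pair shows this change, so a step of any size beyond the scatter is not expected in either direction. Compound 3 is therefore estimated at 16000 nM, between 6000 nM and 40000 nM, an expected step of a 1.2-fold lower number from compound 1 to compound 3 (0.08 log units; within the scatter).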

Compound 3, half-maximal cytotoxic concentration: 29400 nM
Compound 3: the middle estimate sits 1.8-fold (0.26 log units) below what was measured, and the stated range covers the measured number.
By their numbers in this assay, from the lowest: compounds 2, 1 and 3 (each within the scatter of the next).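

In this assay, methoxy in place of hydrogen on an aromatic carbon, para to a large group, gives a 1.5-fold higher number from compound 1 to compound 3 (0.19 log units; within the scatter). For the compounds shown here, this pair is the first direct reading of the change, and it shows that phenyl to 4-methoxyphenyl at this position leaves the number within the scatter. Nothing shown accounts for the size of this step. The compounds shown leave open whether an amine, a carboxylic acid or a longer chain such as ethoxy at this place would move the number beyond the scatter. They also leave open whether methoxy would behave the same way on another aromatic carbon.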